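The compounds below may be only part of what the source reports. "The series", "measured", "known", "first", "only" and "open" are said of these compounds alone.

The series shares one core that carries an ethyl group and a sulfonamide-bearing side chain. Compound 1 `CCn1c([C@@H](C)NS(=O)(=O)c2ccc(Cl)cc2)nc2cc(C#N)ccc21` carries a chlorophenyl group on the sulfonyl sulfur together with a nitrile; in an ADME assay (liver) for metabolic stability, with Liver microsome (Homo sapiens) as the target, read by LC-MS, using microsomes and NADPH, with a stated time of 5 min, at 37 degrees C (a lower number here means slower removal, a higher number faster removal of the compound), compound 1 gives 71 mL.min-1.g-1. Compound 2 `CCn1c(C(C)NS(=O)(=O)c2ccc(Cl)cc2)nc2cccnc21` carries the same chlorophenyl sulfonyl group on a different core, and in this assay compound 2 gives 94 mL.min-1.g-1. Compound 3 `CCn1c([C@@H](C)NS(=O)(=O)C2CC2)nc2ccc(C(F)(F)F)cc21` pairs a trifluoromethyl-bearing core with a cyclopropyl group on the sulfonyl sulfur. In this assay compound 3 returns only a limit, < 3 mL.min-1.g-1. Of the three values shown, compound 3 sits at the low end, as the limit of < 3 mL.min-1.g-1 in this assay, at which 1 of the 3 values shown sits, records. Compound 4 `CCn1c([C@@H](C)NS(=O)(=O)c2cn(C)nc2C)nc2ccc(C(F)(F)F)cc21` keeps the core of compound 3 and differs from it in one place: 1,3-dimethyl-1H-pyrazol-4-yl in place of cyclopropyl on a sulfonyl sulfur. For the measured compounds named here, no measured pair isolates this change. Compound 1 and compound 2 both carry an aromatic ring on the sulfonyl sulfur, and both are removed at a measurable rate, though neither differs from compound 3 in this place alone. The account therefore expects the change to move clearance upward in this assay, beyond the scatter, by roughly an at least 2.6-fold higher number from compound 3 to compound 4 (0.42 log units; beyond the scatter). Compound 4 is estimated to give 8 mL.min-1.g-1 in this assay, within a range from 2 mL.min-1.g-1 to 30 mL.min-1.g-1.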

Compound 4, intrinsic clearance in microsomes: 28 mL.min-1.g-1
The estimate for compound 4 lay 3.5-fold (0.54 log units) below the measured number; the measured number falls inside the stated range.
By their numbers in this assay, from the lowest: compound 4; then compounds 1 and 2 (each within the scatter of the next). At a limit, below all of these: compound 3.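

The sulfonyl position now has its first direct reading: with the core held fixed, 1,3-dimethyl-1H-pyrazol-4-yl in place of cyclopropyl on a sulfonyl sulfur gives an at least 9.3-fold higher number from compound 3 to compound 4 (0.97 log units; beyond the scatter) in this assay. The earlier compounds shown here could not show this, as compound 1 and compound 2 each differ from compound 3 in more than one place, which left the group on the sulfur entangled with the rest of the core. The value of compound 3 is a limit, so the step is known only as a lower bound: the limit of < 3 mL.min-1.g-1 in this assay, at which 1 of the 4 values shown sits.

As far as these compounds go, it remains open whether the step follows from the ring nitrogens, from the two methyl groups or simply from an aromatic ring on the sulfonyl sulfur, and a phenyl ring or an unsubstituted pyrazole on this same core would separate those readings. Also open, from the compounds shown here alone, are how a short open chain such as isopropyl, or a ring carrying an amine, would behave at this place, and whether the step carries over to the cores of compound 1 and compound 2.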